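Benzyl in place of dimethylphenyl on the amine nitrogen

A few compounds are considered here, and "the series" means these few. Any claim that something is new, unique, unknown or untested is made for them only; others in the source may bear on it.

Measured compounds in a functional assay on ECa-109 cells for inhibition, with ECa-109 cell line (Homo sapiens) as the target, read by sulforhodamine B assay; on this read-out higher numbers stand for weaker inhibition and lower numbers for stronger inhibition:
compound 1, `O=C1C(Nc2ccc(Br)cc2)=CC(=O)c2c1nc1n2[C@H]2OC[C@@H](O)[C@H]2OC1`, 1980 nM
compound 2, `Cc1ccc(NC2=CC(=O)c3c(nc4n3[C@H]3OC[C@@H](O)[C@H]3OC4)C2=O)cc1C`, 4090 nM
compound 3, `CCOc1ccc(NC2=CC(=O)c3nc4n(c3C2=O)[C@H]2OC[C@@H](O)[C@H]2OC4)cc1`, 3210 nM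

Going by the values given here, compound 2 stands highest of the three numbers, but its neighbour compound 3 lies within the scatter of it; only the step of a 2.1-fold higher number from compound 1 to compound 2 (0.32 log units; beyond the scatter) is beyond the scatter, and that step is modest. Compound 4, `O=C1C(NCc2ccccc2)=CC(=O)c2c1nc1n2[C@H]2OC[C@@H](O)[C@H]2OC1`, differs from compound 2 by benzyl in place of 3,4-dimethylphenyl on an amine nitrogen. Among the compounds with values here, no measured step exchanges an aryl group for a benzyl group, so nothing bears on this change directly; the only step on the same nitrogen, a 2.1-fold higher number from compound 1 to compound 2 (0.32 log units; beyond the scatter), swaps one aryl substituent pattern for another and is small. A change near the scatter is therefore expected, in no firm direction. Compound 4 is estimated at 3500 nM, between 1200 nM and 10000 nM, an expected step of a 1.2-fold lower number from compound 2 to compound 4 (0.07 log units; within the scatter).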

Compound 4, half-maximal inhibitory concentration: > 8000 nM
Compound 4: a limit, no number (the forecaster's own chance of this, stated with the estimate: 5%); middle value at least 2.2-fold (0.35 log units) away from the limit.
By their numbers in this assay, from the lowest: compounds 1, 3 and 2 (each within the scatter of the next, the first and the last beyond it). At a limit, above all of these: compound 4.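

In this assay compound 4 gives a limit rather than a number, > 8000 nM. Going by these compounds alone, this is the first change on this amine nitrogen that leaves the aryl series, and benzyl in place of 4-bromophenyl weakens inhibition, with an at least 4.0-fold higher number from compound 1 to compound 4 (0.60 log units; beyond the scatter). Against 3,4-dimethylphenyl the result is less firm: an at least 1.9-fold higher number from compound 2 to compound 4 (0.29 log units; that floor lies within the scatter), so a real loss from that group is not established.

On these data alone, how far the loss runs stays open, as does whether a phenethyl group, a plain alkyl chain or a bromobenzyl group on this nitrogen would behave like benzyl.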